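A few compounds are considered here, and "the series" means these few. Any claim that something is new, unique, unknown or untested is made for them only; others in the source may bear on it.

Measured so far in a functional assay on PC-3 cells (Homo sapiens) for cytotoxicity, read by MTT assay, with a stated time of 48 h; on this read-out lower numbers stand for stronger inhibition and higher numbers for weaker inhibition:
Compound 1, `CC1=NN(C(=O)c2ccc([N+](=O)[O-])cc2)C(c2ccccc2O)C1`, gives 36600 nM.
Compound 2, `CC1=NN(C(=O)c2ccc(C)cc2)C(c2ccccc2O)C1`, gives 40600 nM.
Compound 3, `CC1=NN(S(=O)(=O)c2ccc([N+](=O)[O-])cc2)C(c2cc(Br)cc(Br)c2O)C1`, gives 50000 nM.

Compound 1 and compound 2 share one core and differ in a single spot, (methyl in place of nitro on an aromatic carbon). That change produced a step of a 1.1-fold higher number from compound 1 to compound 2 (0.05 log units; within the scatter), so the two compounds behave alike in this assay. Compound 3 rests on a different core, and the difference between the two cores is not broken down here; its number and those of compound 1 and compound 2 all lie within the usual scatter of one another.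

Compound 4, `CC1=NN(S(=O)(=O)c2ccc(C)cc2)C(c2cc(Br)cc(Br)c2O)C1`, has not yet been measured. It relates to compound 3 exactly as compound 2 relates to compound 1: methyl in place of nitro on an aromatic carbon. The same change thus appears twice among these four compounds. Because a 1.1-fold higher number from compound 1 to compound 2 (0.05 log units; within the scatter) stayed within the scatter, the change on the core of compound 3 is expected to move the number only a little, and the expected step is a 1.1-fold higher number from compound 3 to compound 4 (0.04 log units; within the scatter). Compound 4 is therefore estimated at 55000 nM in this assay, most likely between 30000 nM and 100000 nM.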

Compound 4, half-maximal inhibitory concentration: 51200 nM
Compound 4: middle estimate off by 1.1-fold (0.03 log units), on the high side, and the stated range covers the measured number.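

In this assay, putting methyl in place of nitro on the core of compound 3 gave a 1.0-fold higher number from compound 3 to compound 4 (0.01 log units; within the scatter), so the change again left the number within the scatter. Set side by side, the two steps agree: the same change on two cores in this assay, a 1.1-fold higher number (0.05 log units; within the scatter) from compound 1 to compound 2 and a 1.0-fold higher number (0.01 log units; within the scatter) from compound 3 to compound 4, 1.1-fold (0.03 log units) apart, within the scatter of two such steps. This shows that the swap from 4-nitrophenyl to 4-methylphenyl makes no readable difference on either core in this assay. Among the compounds shown here, it does not show that an effect of this change carries over from one core to another, as neither step is large enough to reveal such an effect, and only two cores are compared.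

The compounds shown leave open whether a different group at the same place, such as an amine or a carboxylic acid, would move the number beyond the scatter. They also leave open what each difference between the two cores contributes, as compound 1 and compound 3 differ in more than one place.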